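Cyclohexyl for heptyl: compound 3 in the permeability assay

The source may hold more compounds than are shown below. What is called first, only, known or untested is meant among the compounds shown, and "the series" means these compounds.

Compound 1 `CCc1c(C)[nH]c2cc(OC)c(Cl)cc2c1=O`: 96.4 10^-6 cm/s
Compound 2 `CCCCCCCc1c(C)[nH]c2cc(OC)c(Cl)cc2c1=O`: < 0.01 10^-6 cm/s

In an ADME assay for permeability, using PAMPA, at pH 4 (a higher number here means that the compound crosses the layer faster, a lower number that the compound crosses the layer more slowly), compound 1 gives 96.4 10^-6 cm/s. For compound 2 this assay reports only a limit, < 0.01 10^-6 cm/s. Compound 2 thus sits at the limit of < 0.01 10^-6 cm/s in this assay, at which 1 of the 2 values shown sits. Among the compounds with values here, the single measured step, an at least 9600-fold lower number from compound 1 to compound 2 (3.98 log units; beyond the scatter), is the only guide, and it concerns a chain lengthened rather than reshaped. Compound 3 `COc1cc2[nH]c(C)c(C3CCCCC3)c(=O)c2cc1Cl` differs from compound 2 by cyclohexyl in place of heptyl on an aromatic carbon. Within the data shown here, no measured step matches this swap, so the expectation is loose: compound 3 is expected to move up from the limit by an at least 50-fold higher number from compound 2 to compound 3 (1.69 log units; beyond the scatter), to an estimated 0.5 10^-6 cm/s, within 0.01 10^-6 cm/s to 10 10^-6 cm/s.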

Compound 3, apparent permeability: 1240 10^-6 cm/s
Estimate against measurement, compound 3: 2500-fold (3.39 log units) below, outside the stated range (above it).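

The earlier compounds shown here tied a longer chain at this aromatic carbon only to a collapse in the read-out, but in this assay cyclohexyl gives a 13-fold higher number from compound 1 to compound 3 (1.11 log units; beyond the scatter) and so shows that a larger carbon group here can raise the number. Heptyl and cyclohexyl are both carbon-only groups without hydrogen-bond donors or acceptors, yet an at least 120000-fold higher number from compound 2 to compound 3 (5.09 log units; beyond the scatter) separates them, so carbon count alone does not set the result. Compound 2 stands at a limit, not a number: the limit of < 0.01 10^-6 cm/s in this assay, at which 1 of the 3 values shown sits.

Whether the ring itself matters or branching would suffice stays open, since no isopropyl or tert-butyl group is shown here. As far as these compounds go, how a phenyl ring or a morpholine would read at this position is equally open.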